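Swapping the Amide Substituent on the Weakest Compound

The compounds below may be only part of what the source reports. "The series", "measured", "known", "first", "only" and "open" are said of these compounds alone.

Measured so far:
compound 1 `Cn1ccnc1NC(=O)c1cccc(Nc2ncc(F)c(Nc3ccc(F)cc3)n2)c1`: 14600 nM
compound 2 `CN(C)CC(=O)Nc1cccc(Nc2ncc(F)c(Nc3ccc(F)cc3)n2)c1`: 1260 nM
compound 3 `O=C(Nc1cccc(Nc2ncc(F)c(Nc3ccc(F)cc3)n2)c1)c1ccncc1`: 5280 nM

In a functional assay on KB cells (Homo sapiens) for antiproliferative activity, read by sulforhodamine B assay, with a stated time of 3 days (a lower number here means a stronger inhibitor of growth, a higher number a weaker inhibitor of growth), compound 1 gives the highest of the three numbers, making it the weakest growth inhibitor. Compound 2 sits below it by a 12-fold lower number from compound 1 to compound 2 (1.06 log units; beyond the scatter), and compound 3 by a 2.8-fold lower number from compound 1 to compound 3 (0.44 log units; beyond the scatter). Compound 4 `COc1cc(NC(=O)c2cccc(Nc3ncc(F)c(Nc4ccc(F)cc4)n3)c2)cc(OC)c1` differs from compound 1 by 3,5-dimethoxyphenyl in place of 1-methyl-1H-imidazol-2-yl on an amide-type nitrogen. Neither measured step alters the same part: both rework the group on the carbonyl carbon side, so they bear only loosely on this change. They do show that replacing the substituent carried by compound 1 has so far lowered the number each time. A modest lowering is therefore expected, a 2.9-fold lower number from compound 1 to compound 4 (0.47 log units; beyond the scatter). Compound 4 is estimated at 5000 nM, with a range from 1500 nM to 16000 nM.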

Compound 4, concentration for 50% growth inhibition: 15500 nM
The estimate for compound 4 lay 3.1-fold (0.49 log units) below the measured number; low and high end bracket the measured number.
By their numbers in this assay, from the lowest: compound 2; then compound 3; then compounds 1 and 4 (each within the scatter of the next).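

On this amide-type nitrogen, 3,5-dimethoxyphenyl in place of 1-methyl-1H-imidazol-2-yl gives a 1.1-fold higher number from compound 1 to compound 4 (0.03 log units; within the scatter) in this assay, so the two groups cannot be told apart here. Replacing the substituent of compound 1 therefore does not always lower the number, as the steps to compound 2 and compound 3 had suggested. Nothing measured here explains this flat result. Still open, from the compounds shown here alone, is whether an unsubstituted phenyl, a morpholine or a longer chain on this same nitrogen would shift the number at all.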